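This account rests on a few compounds, and the source may have more. Where it says the series, first, only, none or still open, it means among the compounds named here.

Measured so far:
compound 1, `Nc1n[nH]c2cc(-c3ccc(=O)n(Cc4ccccc4)c3)ccc12`: 79 nM
compound 2, `Nc1n[nH]c2cc(-c3ccc(=O)n(Cc4cccc(Cl)c4)c3)ccc12`: 11 nM

In an assay for inhibition of MAP kinase-interacting serine/threonine-protein kinase 1 (Homo sapiens), read by luminescence and ADP-Glo, with a stated time of 2 h (on this read-out higher numbers stand for weaker inhibition and lower numbers for stronger inhibition), compound 2 gives 11 nM, the lowest of the two numbers. Its nearest neighbour is compound 1, which in this assay gives 79 nM. Among the compounds with values here, the only measured step is a 7.2-fold lower number from compound 1 to compound 2 (0.86 log units; beyond the scatter), a clear gain beyond the scatter. Compound 3, `Nc1n[nH]c2cc(-c3ccc(=O)n(Cc4ccccc4F)c3)ccc12`, keeps the shared core and differs from compound 2 in one place: 2-fluorophenyl in place of 3-chlorophenyl on a saturated chain carbon bound to an aromatic nitrogen. Within the data shown here, no measured step matches this exact change. The move from compound 1 to compound 2 shows that a halogen on this benzyl ring can lower the number, yet compound 3 carries a different halogen in a differently named group, so the measured step is only a loose guide. Compound 3 is therefore expected to give back part of the gain, with an expected step of a 3.6-fold higher number from compound 2 to compound 3 (0.56 log units; beyond the scatter). The estimate for compound 3 in this assay is 40 nM, in the range 15 nM to 120 nM.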

Compound 3, half-maximal inhibitory concentration in the MAP kinase-interacting serine/threonine-protein kinase 1 assay: 12 nM
Beside the measured number, compound 3's estimate is 3.3-fold (0.52 log units) above it, and the stated range ends above it.
By their numbers in the MAP kinase-interacting serine/threonine-protein kinase 1 assay, from the lowest: compounds 2 and 3 (each within the scatter of the next); then compound 1.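

In the MAP kinase-interacting serine/threonine-protein kinase 1 assay, the step of a 6.6-fold lower number from compound 1 to compound 3 (0.82 log units; beyond the scatter) shows that the lower number seen with a chloro group also appears with a fluoro group on this benzyl ring. Replacing 3-chlorobenzyl with 2-fluorobenzyl leaves the two compounds indistinguishable in the MAP kinase-interacting serine/threonine-protein kinase 1 assay, with a 1.1-fold higher number from compound 2 to compound 3 (0.04 log units; within the scatter), so at this position either group serves equally well on this read-out. They do separate in a physicochemical assay for solubility, read by spectrophotometry, measured as kinetic solubility, with a stated time of 1.5 h, at pH 7.4, tested at 500 uM (a lower number here means a less soluble compound, a higher number a more soluble compound), where compound 2 gives 172000 nM and compound 3 gives 466000 nM, which favours the 2-fluorobenzyl group on this second read-out: the measured solubility of compound 2, 172000 nM, and of compound 3, 466000 nM, a 2.7-fold higher number (0.43 log units; beyond the scatter)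

Compounds 2 and 3 differ in both the halogen and its place on the ring, so these two changes cannot be told apart here. From the compounds shown here alone, whether a group other than a halogen on this ring, such as a methoxy group or an amine, would give a similar number remains open.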